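The source may hold more compounds than are shown below. What is called first, only, known or untested is meant among the compounds shown, and "the series" means these compounds.

Compound 1 `Cc1c(OCCCCOc2ccc(C(=O)C(C)C)c(O)c2C)cccc1C(=O)O`: 27.1%
Compound 2 `Cc1cc(OCCCCOc2ccc(C(=O)CC(C)C)c(O)c2C)ccc1C(=O)O`: 41.9%

In an assay on HEK293 cells for positive allosteric modulation of metabotropic glutamate receptor 3 (Rattus norvegicus), read by thallium flux, with a stated time of 2.5 min (on this read-out higher numbers stand for larger maximal responses and lower numbers for smaller maximal responses), compound 1 gives 27.1%, the lowest of the two numbers shown; the nearest, compound 2, lies higher by a gap beyond the scatter. Compound 3 `CC(=O)c1ccc(OCCCCOc2cccc(C(=O)O)c2C)c(C)c1O` has not yet been measured. It differs from compound 1 by methyl in place of isopropyl on a carbonyl carbon. Within the data shown here, no step between two measured compounds exists to gauge such a change, so in this assay a shift within the scatter is expected, in no firm direction. Compound 3 is therefore estimated at 30%, within 15% to 50%. The expected step is a number 2.9 percentage points higher from compound 1 to compound 3 (within the scatter).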

Compound 3, largest response reached (reported as percent of maximum), in percent of the reference or control that the assay uses: 17.1%
For compound 3 the middle estimate is 12.9 percentage points above the measured one; the measured number falls inside the stated range.
By their numbers in this assay, from the lowest: compounds 3 and 1 (each within the scatter of the next); then compound 2.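

Shortening the group on the carbonyl carbon from isopropyl to methyl gives the first measured step at this position: in this assay the change is a number 10 percentage points lower from compound 1 to compound 3 (within the scatter) and so does not separate the two compounds. At this position, then, isopropylcarbonyl and acetyl cannot be told apart on this read-out, even though two carbons are lost. Nothing available explains this result. Still open, going by these compounds, is whether a larger group on the same carbonyl carbon, such as phenyl or cyclohexyl, would move the response beyond the scatter. An amine there, giving an amide, is equally untested among the compounds shown.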